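Adding Methoxy Groups to the Ester Ring of Compound 1

The source may report more compounds than this note shows. Statements on the series, on what has been measured and on what is new or still open speak of the compounds shown alone.

Compound 1 `COC(=O)/C(=C\c1ccc(OC(=O)c2cccc(OC)c2)cc1)Sc1ccnc2cc(Cl)ccc12` is tested in a functional assay on Jurkat E6.1 cells (Homo sapiens) for cytotoxicity, read by MTT assay, with a stated time of 24 h (on this read-out higher numbers stand for weaker inhibition and lower numbers for stronger inhibition), where compound 1 gives 33300 nM, the higher of the two numbers recorded. Going by the values given here, compound 2 `COC(=O)/C(=C\c1ccc(OC(=O)c2ccc(OC)c(OC)c2)cc1)Sc1ccnc2cc(Cl)ccc12` gives 8290 nM in this assay, and the step of a 4.0-fold lower number from compound 1 to compound 2 (0.60 log units; beyond the scatter) is the only measured change that bears on the new compound. Compound 3 `COC(=O)/C(=C\c1ccc(OC(=O)c2cc(OCc3ccccc3)c(OCc3ccccc3)c(OCc3ccccc3)c2)cc1)Sc1ccnc2cc(Cl)ccc12` reaches only a limit of the assay, > 100000 nM, and not a number (the limit of > 100000 nM in this assay, at which 1 of the 3 values shown sits). Compound 4 `COC(=O)/C(=C\c1ccc(OC(=O)c2cc(OC)cc(OC)c2OC)cc1)Sc1ccnc2cc(Cl)ccc12` differs from compound 1 by 2,3,5-trimethoxyphenyl in place of 3-methoxyphenyl on a carbonyl carbon. Because adding a methoxy group lowered the number in a 4.0-fold lower number from compound 1 to compound 2 (0.60 log units; beyond the scatter), compound 4 is expected to show a modest lowering in this assay, a 2.2-fold lower number from compound 1 to compound 4 (0.35 log units; beyond the scatter). Compound 4 is thus estimated at 15000 nM, with a plausible range from 4000 nM to 60000 nM.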

Compound 4, half-maximal inhibitory concentration: 15600 nM
Compound 4: the middle estimate sits 1.0-fold (0.02 log units) below what was measured, within the range that was stated.
By their numbers in this assay, from the lowest: compounds 2 and 4 (each within the scatter of the next); then compound 1. At a limit, above all of these: compound 3.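

In this assay, the 2,3,5-trimethoxyphenyl group on the carbonyl carbon again gives a lower number than the 3-methoxyphenyl group, a 2.1-fold lower number from compound 1 to compound 4 (0.33 log units; beyond the scatter), so a second pattern of added methoxy groups points the same way. Set against the 3,4-dimethoxyphenyl group, the change is a 1.9-fold higher number from compound 2 to compound 4 (0.27 log units; within the scatter), so these two groups cannot be told apart here. Nothing measured here explains either step. The compounds shown leave open whether the count of methoxy groups or their placing matters more, and how a hydroxy group or an amine on this ring would behave.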